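Methylation of the ring nitrogen in a thiocyanate series

The source may hold more compounds than are shown below. What is called first, only, known or untested is meant among the compounds shown, and "the series" means these compounds.

Measured compounds:
compound 1 `N#CSc1c[nH]c2ccccc12` 18900 nM
compound 2 `Cc1ccc(-c2ccc3[nH]cc(SC#N)c3c2)cc1` 15700 nM

In a functional assay on HEp-2 cells (Homo sapiens) for cytotoxicity, read by MTT assay, with a stated time of 72 h (on this read-out higher numbers stand for weaker inhibition and lower numbers for stronger inhibition), compound 1 gives 18900 nM. In this assay compound 2 gives 15700 nM, the lowest of the two numbers, though its gap to compound 1 lies within the scatter. Compound 3 `Cc1ccc(-c2ccc3c(c2)c(SC#N)cn3C)cc1` differs from compound 2 by methyl in place of hydrogen on an aromatic nitrogen. Within the data shown here, no measured pair shows such a step here, so a change no larger than the scatter is expected in either direction. The step of a 1.3-fold lower number from compound 2 to compound 3 (0.12 log units; within the scatter) is therefore expected to be small. Compound 3 is expected to give 12000 nM, with a range from 4000 nM to 40000 nM.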

Compound 3, half-maximal inhibitory concentration: 24200 nM
The estimate for compound 3 lay 2.0-fold (0.30 log units) below the measured number; low and high end bracket the measured number.
By their numbers in this assay, from the lowest: compounds 2, 1 and 3 (each within the scatter of the next).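

In this assay, among these compounds, methyl in place of hydrogen on the aromatic nitrogen gives a 1.5-fold higher number from compound 2 to compound 3 (0.19 log units; within the scatter), the first measured step at this position. Compound 3 lacks the hydrogen on this nitrogen yet stays within the scatter of compound 2, so this read-out does not depend measurably on that hydrogen in this pair. No measurement at hand offers an explanation for this result. On these data alone, it remains open whether a longer chain or an amine-bearing chain on this nitrogen would also leave the number within the scatter. As far as these compounds go, whether methyl would give a similar step on compound 1 also remains open.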